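This account rests on a few compounds, and the source may have more. Where it says the series, first, only, none or still open, it means among the compounds named here.

Of the compounds shown here, three have so far been measured in a functional assay on the whole organism for inhibition, with Nicotiana tabacum as the target; a lower number here means a stronger inhibitor, a higher number a weaker inhibitor. Compound 1 `Cc1nc(Nc2ccc(F)cc2)c2cc[nH]c2n1` gives 372000000 nM, compound 2 `Cc1nc(Nc2ccc(I)cc2)c2cc[nH]c2n1` gives 219000000 nM and compound 3 `COc1ccc(Nc2[nH]c(C)nc3nccc2-3)cc1` gives 661000000 nM. Compound 2 stands at the lowest number of the three; the gap to compound 1 is within the scatter, the gap to compound 3 beyond it. Compound 4 `Cc1nc(Nc2ccc(C(F)(F)F)cc2)c2cc[nH]c2n1` differs from compound 2 by trifluoromethyl in place of iodo on an aromatic carbon. Among the compounds with values here, the only measured step at that aromatic carbon, a 1.7-fold lower number from compound 1 to compound 2 (0.23 log units; within the scatter), stayed within the scatter. Within the data shown here, no measured step covers a trifluoromethyl group, so nothing more bears on the change, and no step beyond the scatter is expected in this assay in either direction. For compound 4 the expected value is 250000000 nM, with a range from 100000000 nM to 600000000 nM. This expectation corresponds to a 1.1-fold higher number from compound 2 to compound 4 (0.06 log units; within the scatter).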

Compound 4, half-maximal inhibitory concentration: 70800000 nM
Estimate against measurement, compound 4: 3.5-fold (0.55 log units) above; measured number below the stated range.
By their numbers in this assay, from the lowest: compound 4; then compounds 2, 1 and 3 (each within the scatter of the next, the first and the last beyond it).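

At this aromatic carbon, in this assay, the substituent now makes a difference beyond the scatter: trifluoromethyl lowers the number both in place of iodo (a 3.1-fold lower number from compound 2 to compound 4 (0.49 log units; beyond the scatter)) and in place of fluoro (a 5.3-fold lower number from compound 1 to compound 4 (0.72 log units; beyond the scatter)). The position therefore responds to change, which the step between fluoro and iodo alone did not show. No measurement at hand accounts for this difference.

Going by these compounds, whether a nitrile, an amine or a carboxylic acid at this carbon would also lower the number remains open. Also open, on these data alone, is whether the trifluoromethyl step holds with other changes on the shared core.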